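The source may report more compounds than this note shows. Statements on the series, on what has been measured and on what is new or still open speak of the compounds shown alone.

Within the data shown here, compound 2 `COc1ccc(-c2ocnc2-c2cc(Br)c(OC)c(OC)c2)cc1OC` is the only compound in this set for which a functional assay on A549 cells (Homo sapiens) for cytotoxicity, read by MTT assay, with a stated time of 48 h (a higher number here means a weaker inhibitor, a lower number a stronger inhibitor), gives a number: in this assay compound 2 gives 500 nM. Compound 1 `COc1ccc(-c2ocnc2-c2cc(OC)c(OC)c(OC)c2)cc1S` is the other member, and in this assay compound 1 reaches only > 20000 nM, which is a limit of the assay rather than a number; the limit of > 20000 nM in this assay, at which 1 of the 2 values shown sits, marks it as such. Among the measured compounds shown here, compound 1 and compound 2 differ in more than one place, so the two values show only that one is a number and the other a limit.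

Compound 3 `COc1ccc(-c2ocnc2-c2cc(Br)c(OC)c(OC)c2)cc1SC` has not yet been measured in this assay. It differs from compound 2 by methylsulfanyl in place of methoxy on an aromatic carbon.

No measured pair in this set differs in one place, so the size of the step from compound 2 to compound 3 can only be expected, not drawn from a shown step. The exchange of methoxy for methylsulfanyl is expected to cost some potency, and the step from compound 2 to compound 3 is estimated at a 2.4-fold higher number from compound 2 to compound 3 (0.38 log units; beyond the scatter). For compound 3 in this assay the estimate is therefore 1200 nM, with a range from 300 nM to 5000 nM.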

Compound 3, half-maximal inhibitory concentration: > 20000 nM
Compound 3: no number, only a limit; the forecaster's own chance of this, stated with the estimate: 10%; middle value at least 16-fold (1.22 log units) from the limit.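

In this assay, among these compounds, this is the first comparison in the set across a single change: methylsulfanyl in place of methoxy on an aromatic carbon, ortho to a methoxy group and meta to a large group, gives an at least 40-fold higher number from compound 2 to compound 3 (1.60 log units; beyond the scatter). Among the compounds shown here, the earlier compounds could not show this, since compound 1 and compound 2 differ in more than one place, whereas here the one exchange alone separates a compound with a measured number from one without a number, so activity depends strongly on what sits at this position. Compound 3 gives > 20000 nM, which is a limit of the assay and not a number, so the step gives only a minimum for the change, and this limit is shared within the set: the limit of > 20000 nM in this assay, at which 2 of the 3 values shown sit.

The compounds shown leave open how a hydroxyl, an ethoxy or an amine would read at this position, and so whether methoxy is unusually favourable there or methylsulfanyl is unusually poor. They also leave open whether the same exchange would have a comparable effect at either of the other methoxy groups of compound 2.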